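A tert-butoxycarbonyl group gives way to acetyl

A few compounds are considered here, and "the series" means these few. Any claim that something is new, unique, unknown or untested is made for them only; others in the source may bear on it.

In a physicochemical assay for solubility (on this read-out lower numbers stand for lower solubility and higher numbers for higher solubility), compound 1 `O=C(CN1CCCC1)N1CCC(NS(=O)(=O)c2cc(S(=O)(=O)c3ccccc3)ccc2C(F)(F)F)CC1` gives 25000 nM and compound 2 `CC(C)(C)OC(=O)N1CCC[C@@H]1C(=O)N1CCC(NS(=O)(=O)c2cc(S(=O)(=O)c3ccccc3)ccc2C(F)(F)F)CC1` gives 25000 nM as well, so compound 2 stands level with compound 1. Compound 3 `CC(=O)N1CCC[C@H]1C(=O)N1CCC(NS(=O)(=O)c2cc(S(=O)(=O)c3ccccc3)ccc2C(F)(F)F)CC1` keeps the shared core but carries 1-acetylpyrrolidin-2-yl in place of 1-(tert-butoxycarbonyl)pyrrolidin-2-yl on a carbonyl carbon. Within the data shown here, one measured step bears on this, also made on a carbonyl carbon: that move (no change at the digits printed from compound 1 to compound 2 (within the scatter)) put 1-(tert-butoxycarbonyl)pyrrolidin-2-yl in place of (pyrrolidin-1-yl)methyl. A single step is thin evidence, but it gives no sign of movement, so no shift beyond the scatter is expected in this assay for the new change (no change at the digits printed from compound 2 to compound 3 (within the scatter)). Compound 3 is estimated at 25000 nM with an expected range from 14000 nM to 35000 nM on this read-out.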

Compound 3, solubility: 12500 nM
For compound 3 the middle estimate is 2.0-fold (0.30 log units) above the measured one; the measured number lies below the stated range.
By their numbers in this assay, from the lowest: compounds 3, 1 and 2 (each within the scatter of the next).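

At this carbonyl carbon, 1-acetylpyrrolidin-2-yl in place of 1-(tert-butoxycarbonyl)pyrrolidin-2-yl gives a 2.0-fold lower number from compound 2 to compound 3 (0.30 log units; within the scatter) in this assay. Measured against (pyrrolidin-1-yl)methyl, the same acetyl group gives a 2.0-fold lower number from compound 1 to compound 3 (0.30 log units; within the scatter), so all three groups seen at this place now stand within the scatter of one another. Nothing available explains these numbers.

The compounds shown leave open whether a different kind of group on this carbonyl carbon, such as a carboxylic acid or a longer chain ending in an amine, would shift this read-out beyond the scatter. They also leave open where an unsubstituted pyrrolidin-2-yl would stand.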